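Replacing a dichlorophenyl with a nitrophenyl on a hydrazone

This account rests on a few compounds, and the source may have more. Where it says the series, first, only, none or still open, it means among the compounds named here.

Three hydrazones sharing one core have been measured in a functional assay on A549 cells (Homo sapiens) for antiproliferative activity, read by MTT assay; a higher number here means a weaker inhibitor, a lower number a stronger inhibitor. Compound 1 `Cn1c(=O)c(=O)n(C2CCCC2)c2nc(N/N=C/c3ccc(Cl)cc3)ncc21` gives 6890 nM. Compound 2 `Cn1c(=O)c(=O)n(C2CCCC2)c2nc(N/N=C/c3cccc(Cl)c3Cl)ncc21` gives 39100 nM, and compound 3 `Cn1c(=O)c(=O)n(C2CCCC2)c2nc(N/N=C/c3ccc(F)cc3Cl)ncc21` gives 11000 nM. Compound 2 stands at the highest number of the three: compound 3 is its nearest neighbour, and compound 1 is furthest from it. The measured steps among the three are a 5.7-fold higher number from compound 1 to compound 2 (0.75 log units; beyond the scatter), a 1.6-fold higher number from compound 1 to compound 3 (0.20 log units; within the scatter) and a 3.6-fold lower number from compound 2 to compound 3 (0.55 log units; beyond the scatter).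

Compound 4 `Cn1c(=O)c(=O)n(C2CCCC2)c2nc(N/N=C/c3cccc([N+](=O)[O-])c3)ncc21` differs from compound 2 as follows: 3-nitrophenyl in place of 2,3-dichlorophenyl on a carbon with a double bond to nitrogen. For the measured compounds named here, both steps that leave compound 2, or arrive at it, are modest and point the same way, with compound 2 at the high end; no measured compound carries a nitro group, so the change itself is untested. Because of a 3.6-fold lower number from compound 2 to compound 3 (0.55 log units; beyond the scatter) and a 5.7-fold higher number from compound 1 to compound 2 (0.75 log units; beyond the scatter), a move away from compound 2 is expected to give a lower number in this assay, and the step is estimated as a 3.3-fold lower number from compound 2 to compound 4 (0.51 log units; beyond the scatter). Compound 4 is therefore expected at 12000 nM, with a range from 4000 nM to 40000 nM.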

Compound 4, half-maximal inhibitory concentration: 12300 nM
For compound 4 the middle estimate is 1.0-fold (0.01 log units) below the measured one, and the stated range covers the measured number.
By their numbers in this assay, from the lowest: compounds 1, 3 and 4 (each within the scatter of the next); then compound 2.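

In this assay, 3-nitrophenyl in place of 2,3-dichlorophenyl gives a 3.2-fold lower number from compound 2 to compound 4 (0.50 log units; beyond the scatter), so a phenyl group carrying no chlorine also stands clear of compound 2. Against the other two compounds, the steps are a 1.1-fold higher number from compound 3 to compound 4 (0.05 log units; within the scatter) and a 1.8-fold higher number from compound 1 to compound 4 (0.25 log units; within the scatter), which leaves compound 4 indistinguishable from both. On the carbon with a double bond to nitrogen, a nitro-bearing ring therefore fits with the chlorinated rings of compound 1 and compound 3, while compound 2 alone stands apart among the four.

Whether an amine or a carboxylic acid on the phenyl ring, in place of the nitro group, would stay in this range remains open, and no evidence given here accounts for the position of compound 2.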